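Moving the substituent on the azo-linked phenyl ring

The source may report more compounds than this note shows. Statements on the series, on what has been measured and on what is new or still open speak of the compounds shown alone.

Compound 1 `COc1n[nH]c2ncc(NC(=O)c3c(F)ccc(/N=N\c4ccccc4F)c3F)cc12`: 5 h
Compound 2 `COc1n[nH]c2ncc(NC(=O)c3c(F)ccc(/N=N\c4ccc(C)cc4)c3F)cc12`: > 24 h
Compound 3 `COc1n[nH]c2ncc(NC(=O)c3c(F)ccc(/N=N\c4ccc(F)cc4)c3F)cc12`: > 24 h

In an unclassified assay for pharmacokinetics, read by NMR, at pH 7.5, tested at 2 mg/mL (on this read-out lower numbers stand for a shorter-lived compound and higher numbers for a longer-lived compound), compound 3 gives only a limit, not a number. Compound 2 also gives only a limit in this assay. Compound 1 gives a real number, and an at least 4.8-fold higher number from compound 1 to compound 3 (0.68 log units; beyond the scatter), while a step that the two limits leave unreadable from compound 2 to compound 3.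

Compound 4 `COc1ccccc1/N=N\c1ccc(F)c(C(=O)Nc2cnc3[nH]nc(OC)c3c2)c1F` differs from compound 3 as follows: 2-methoxyphenyl in place of 4-fluorophenyl on a double-bonded nitrogen. This change partly reverses the step from compound 1 to compound 3, as both compound 1 and compound 4 carry a substituent on the same position of that phenyl ring. A drop in this assay is therefore expected, estimated as an at least 4.0-fold lower number from compound 3 to compound 4 (0.60 log units; beyond the scatter). Compound 4 is expected to give about 6 h, within 2 h to 24 h.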

Compound 4, half-life: > 24 h
Compound 4 gave a limit, no number; the forecaster's own chance of this, stated with the estimate: 20%; at least 4.0-fold (0.60 log units) between middle value and limit.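

In this assay, having a substituent at this place on the phenyl ring does not by itself give a short half-life: methoxy in place of fluoro gives an at least 4.8-fold higher number from compound 1 to compound 4 (0.68 log units; beyond the scatter). Among the compounds shown, only the 2-fluorophenyl group of compound 1 goes with a short half-life, and the value of compound 4 is a limit, not a number. The steps from compound 2 and compound 3 to compound 4 cannot be read, because these values all stop at the same point: the limit of > 24 h in this assay, at which 3 of the 4 values shown sit.

From the compounds shown here alone, how long-lived compound 2, compound 3 and compound 4 really are stays open. So does the effect of an amine or a carboxylic acid in place of the methoxy of compound 4.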